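Cyano to Methyl on the Pyridine of a Urea Antagonist

The source may hold more compounds than are shown below. What is called first, only, known or untested is meant among the compounds shown, and "the series" means these compounds.

Three compounds have numbers in a functional assay on HFL1 cells for antagonist activity at sphingosine 1-phosphate receptor 2 (Homo sapiens), read by ELISA, with a stated time of 24 h, in the absence of a further agent; on this read-out lower numbers stand for stronger inhibition and higher numbers for weaker inhibition. Compound 1, `Cc1cc(CNC(=O)c2cc3c(Cl)nc(Cl)cc3[nH]2)ncc1-c1cn(C)nc1C`, gives 1.3 nM in this assay. Compound 2, `CCOc1cc(NC(=O)NCc2cc(C)c(N3CC(C)OC(C)C3)cn2)cc(Cl)n1`, gives 105 nM in this assay. Compound 3, `CCOc1cc(NC(=O)NCc2cc(C)c(-c3cn(C)nc3C(F)(F)F)nn2)cc(C#N)n1`, gives 35 nM in this assay, which places it second highest of the three: its nearest neighbour is compound 2, whose number lies beyond the scatter above it, and its furthest is compound 1, whose number lies far beyond the scatter below it.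

Compound 4, `CCOc1cc(NC(=O)NCc2cc(C)c(-c3cn(C)nc3C(F)(F)F)nn2)cc(C)n1`, has not yet been measured in this assay. It differs from compound 3 in one place: methyl in place of cyano on an aromatic carbon. For the measured compounds named here, no pair of measured compounds differs by this change alone, so its size has to be guessed. The account expects at most a modest step from compound 3 to compound 4, probably toward a weaker number, and possibly none beyond the scatter. The estimated step is a 1.7-fold higher number from compound 3 to compound 4 (0.23 log units; within the scatter). For compound 4 in this assay the expected value is 60 nM, with a range from 15 nM to 250 nM.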

Compound 4, half-maximal inhibitory concentration: 242 nM
Compound 4: the middle estimate sits 4.0-fold (0.61 log units) below what was measured, within the range that was stated.
By their numbers in this assay, from the lowest: compound 1; then compound 3; then compound 2; then compound 4.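

In this assay, the step is a 6.9-fold higher number from compound 3 to compound 4 (0.84 log units; beyond the scatter), which lies beyond the scatter and shows that the read-out responds to the group on this aromatic carbon next to the ring nitrogen. For the compounds shown here, no earlier pair had isolated this place, and here a single change, 2-cyano-6-ethoxypyridin-4-yl to 2-ethoxy-6-methylpyridin-4-yl, is enough to move the number, with the rest of the molecule held constant. Nothing available on these compounds accounts for the direction or size of this step.

The compounds shown leave open where an amine, a methoxy group or a carboxylic acid on this same carbon would fall relative to cyano and methyl. They also leave open whether the same swap would give a step of similar size on a different core, such as that of compound 1.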